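Series notes: benzylamino variation on a shared triazine-type core

A few compounds are considered here, and "the series" means these few. Any claim that something is new, unique, unknown or untested is made for them only; others in the source may bear on it.

Measured so far:
compound 1, `Nc1nc(NCc2cccc(F)c2)nc(-c2ccccc2CO)n1`, 4.52
compound 2, `Nc1nc(NCc2ccccc2Cl)nc(-c2ccccc2CO)n1`, 5.07

Compound 1 is the lower of the two numbers in a functional assay on cells for positive allosteric modulation of G-protein coupled receptor 68 (Homo sapiens), read by a luciferase reporter and cAMP accumulation, with a stated time of 30 min, at pH 6.8 and pH 8.3, in the presence of a further agent that is not named here; a higher number here means a more potent compound, by a factor of ten per unit of this negative logarithm, a lower number a less potent compound. Among the compounds with values here, its nearest neighbour is compound 2, and the single change a number 0.55 log units higher from compound 1 to compound 2 (beyond the scatter) puts compound 2 above it by a modest margin beyond the scatter.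

Compound 3 is `Nc1nc(NCc2cccc(C(F)(F)F)c2)nc(-c2ccccc2CO)n1` and has not yet been run in this assay. Relative to compound 1 it carries trifluoromethyl in place of fluoro on an aromatic carbon, the new group sitting on an aromatic carbon of a six-membered aromatic ring of carbon only, meta to a large group. Within the data shown here, no measured step alters this position; the only step recorded, from compound 1 to compound 2, changes both the halogen and its place on the ring, so it gives only indirect guidance. A small upward move is therefore expected, a number 0.28 log units higher from compound 1 to compound 3 (within the scatter), with wide uncertainty. For compound 3 the expected value in this assay is 4.8, with a range from 4.3 to 5.4.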

Compound 3, negative logarithm of the antagonist equilibrium constant: 5.11
Estimate against measurement, compound 3: 0.31 log units below; low and high end bracket the measured number.
By their numbers in this assay, from the lowest: compound 1; then compounds 2 and 3 (each within the scatter of the next).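

Trifluoromethyl in place of fluoro, with the place on the ring unchanged, gives a number 0.59 log units higher from compound 1 to compound 3 (beyond the scatter) in this assay. Unlike the step to compound 2, which alters both the halogen and its place, this step isolates the group itself: this aromatic carbon, meta to a large group, takes 4 heavy atoms in place of 1 with a gain rather than a loss in the number. Nothing available here accounts for the rise.

With only fluoro and trifluoromethyl shown at this place, it remains open whether the number follows the size of the group or something specific to fluorine-bearing groups. A methyl group, a nitrile or a carboxylic acid on the same aromatic carbon would help separate these readings.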